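Removing One Methoxy Group from Compound 1

This account rests on a few compounds, and the source may have more. Where it says the series, first, only, none or still open, it means among the compounds named here.

Compound 1 `COc1cc(-c2cc(/C=C/C(=O)c3ccc(N)cc3)[nH]n2)cc(OC)c1OC` gives 1410 nM in a functional assay on KM12 cells (Homo sapiens) for inhibition, read by sulforhodamine B assay, with a stated time of 48 h (a higher number here means a weaker inhibitor of growth, a lower number a stronger inhibitor of growth), the second highest of the three numbers available. Compound 2 `COc1ccc(-c2cc(/C=C/C(=O)c3ccc(OC)c(OC)c3)[nH]n2)cc1` gives 1380 nM in this assay, a value within the scatter of that of compound 1. Compound 3 `COc1cc(-c2cc(/C=C/C(=O)c3ccc(Cl)c(Cl)c3)[nH]n2)cc(OC)c1OC` gives 3370 nM in this assay. Going by the values given here, the only measured single change is a 2.4-fold higher number from compound 1 to compound 3 (0.38 log units; beyond the scatter), and it concerns the aryl group on the carbonyl carbon, not the site altered here. Compound 4 `COc1ccc(-c2cc(/C=C/C(=O)c3ccc(N)cc3)[nH]n2)cc1OC` differs from compound 1 by hydrogen in place of methoxy on an aromatic carbon. Among the compounds with values here, no measured step tests this change, so no shift beyond the scatter is expected in this assay. The number for compound 4 is estimated at 1500 nM, between 600 nM and 4000 nM. That estimate means an expected step of a 1.1-fold higher number from compound 1 to compound 4 (0.03 log units; within the scatter).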

Compound 4, concentration for 50% growth inhibition: 1680 nM
Estimate against measurement, compound 4: 1.1-fold (0.05 log units) below; measured number inside the range.
By their numbers in this assay, from the lowest: compounds 2, 1, 4 and 3 (each within the scatter of the next, the first and the last beyond it).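

Hydrogen in place of methoxy on this aromatic carbon, ortho to a methoxy group, brings a 1.2-fold higher number from compound 1 to compound 4 (0.08 log units; within the scatter) in this assay and so leaves the number unshifted beyond the scatter in this pair. Going by these compounds alone, this is the first measured step at this position, since the earlier step concerned the aryl group on the carbonyl carbon. The data offer no evidence on why the number holds. Open, on these data alone, is how a hydroxyl group, an ethoxy group or a fluorine atom on this carbon would read, and whether the same change holds with another aryl group on the carbonyl carbon.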